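The source may report more compounds than this note shows. Statements on the series, on what has been measured and on what is new or still open speak of the compounds shown alone.

Measured so far in an assay on HeLa cells for displacement of a labelled ligand from 5-hydroxytryptamine receptor 6 (Homo sapiens); on this read-out lower numbers stand for stronger inhibition and higher numbers for weaker inhibition:
- compound 1 `O=S(=O)(c1cccc(F)c1)c1cn(C2CCNC2)c2ncccc12` gives 2.7 nM
- compound 2 `CCN1CCC(n2cc(S(=O)(=O)c3cccc(F)c3)c3cccnc32)C1` gives 8.3 nM
- compound 3 `CN1CCCC(n2cc(S(=O)(=O)c3cccc(F)c3)c3cccnc32)C1` gives 4.7 nM

Compound 3 sits second highest of the three, its number within the scatter of both neighbours, a 1.7-fold higher number from compound 1 to compound 3 (0.24 log units; within the scatter) and a 1.8-fold lower number from compound 2 to compound 3 (0.25 log units; within the scatter). Compound 4 `CCN1CCCC(n2cc(S(=O)(=O)c3cccc(F)c3)c3cccnc32)C1` differs from compound 3 by methyl in place of hydrogen on a saturated chain carbon bound to an amine nitrogen in a ring. Within the data shown here, the one measured step that bears on this, alkyl growth on the ring amine nitrogen, is a 3.1-fold higher number from compound 1 to compound 2 (0.49 log units; beyond the scatter), a modest rise; the step from methyl to ethyl here is expected to be smaller than that. Compound 4 is therefore expected to give 7 nM (range 3 nM to 16 nM), a step of a 1.5-fold higher number from compound 3 to compound 4 (0.17 log units; within the scatter), at the edge of the scatter.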

Compound 4, inhibition constant: 4.4 nM
Compound 4: the middle estimate sits 1.6-fold (0.20 log units) above what was measured; low and high end bracket the measured number.
By their numbers in this assay, from the lowest: compounds 1, 4, 3 and 2 (each within the scatter of the next, the first and the last beyond it).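

In this assay, the change from 1-methylpiperidin-3-yl to 1-ethylpiperidin-3-yl on the aromatic nitrogen leaves the number within the scatter (a 1.1-fold lower number from compound 3 to compound 4 (0.03 log units; within the scatter)), so this added methyl has no measurable effect here. Compound 4 also lies within the scatter of both other compounds (a 1.9-fold lower number from compound 2 to compound 4 (0.28 log units; within the scatter) and a 1.6-fold higher number from compound 1 to compound 4 (0.21 log units; within the scatter)), although compound 1 and compound 2 lie beyond the scatter of each other. No available evidence accounts for this result. From the compounds shown here alone, whether a propyl group, a longer chain or a hydroxyethyl group on that ring amine nitrogen would stay within the scatter remains open.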